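A few compounds are considered here, and "the series" means these few. Any claim that something is new, unique, unknown or untested is made for them only; others in the source may bear on it.

Of the compounds shown here, three built on one shared core have been measured in an assay on CHO cells for displacement of a labelled ligand from adenosine receptor A1 (Homo sapiens), read by scintillation counting, tested at 1 uM; a higher number here means more inhibition at the concentration tested (going by the name of the read-out), a lower number less inhibition. Compound 1 `CC(C)Cc1nc(N)c2nn(-c3ccccc3)cc2n1` gives 49%. Compound 2 `COc1ccc(Cc2nc(N)c3nn(-c4ccccc4)cc3n2)cc1` gives 48%, and compound 3 `Cc1ccc(Cc2nc(N)c3nn(-c4ccccc4)cc3n2)cc1` gives 38%. Compound 3 holds the lowest of the three numbers, though not by much: the step of a number 11 percentage points lower from compound 1 to compound 3 (beyond the scatter) lies beyond the scatter, whereas the step of a number 10 percentage points lower from compound 2 to compound 3 (within the scatter) and the step of a number 1 percentage points lower from compound 1 to compound 2 (within the scatter) both lie within it, so the number of compound 3 is lower than that of compound 1 but level with that of compound 2.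

Compound 4 `Nc1nc(Cc2ccc(Cl)cc2)nc2cn(-c3ccccc3)nc12` differs from compound 3 in one place: chloro in place of methyl on an aromatic carbon. Within the data shown here, only one measured step alters a group on that same aromatic carbon, namely a number 10 percentage points lower from compound 2 to compound 3 (within the scatter), and it stayed within the scatter. Among the measured compounds shown here, no measured pair exchanges methyl for chloro, so the data give no direct guide to that exchange. For the measured compounds named here, since the one change already seen at this carbon shifted the number only within the scatter, the step of a number 4 percentage points higher from compound 3 to compound 4 (within the scatter) is expected to remain within the scatter as well, with no direction favoured. Compound 4 is therefore expected to give about 42% in this assay. Its estimate is expected to fall between 28% and 58%.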

Compound 4, a percentage reported as inhibition, at one concentration (the size of the read-out at that concentration, not a potency): 49%
For compound 4 the middle estimate is 7 percentage points below the measured one; low and high end bracket the measured number.
By their numbers in this assay, from the lowest: compounds 3, 2, 1 and 4 (each within the scatter of the next, the first and the last beyond it).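

In this assay, among these compounds, this aromatic carbon now gives a step beyond the scatter, a number 11 percentage points higher from compound 3 to compound 4 (beyond the scatter), with chloro in place of methyl, whereas the only earlier change there, methyl in place of methoxy, stayed within it. Chloro and methoxy on this carbon cannot be told apart, a number 1 percentage points higher from compound 2 to compound 4 (within the scatter), and the 4-chlorophenyl group also reads level with the isopropyl of compound 1, no change at the digits printed from compound 1 to compound 4 (within the scatter), so compound 3 is set apart from compound 1 and compound 4 while remaining within the scatter of compound 2. Nothing available gives a reason for the difference between methyl and chloro at this carbon.

The compounds shown leave open how an amine or a carboxylic acid on this same aromatic carbon would read in this assay, and whether bromo would fall level with chloro or with methyl. They also leave open whether chloro would give the same step elsewhere on the ring, since each substituent compared here sits para to a large group.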